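Phenyl in Place of Pyridin-4-yl: What to Expect

The source may report more compounds than this note shows. Statements on the series, on what has been measured and on what is new or still open speak of the compounds shown alone.

Compound 1 `COC(=O)C[C@H](O)C[C@H](O)/C=C/n1c(-c2ccc(F)cc2)c(-c2ccc(F)cc2)c(Br)c1C(C)C`: 0.3 nM
Compound 2 `COC(=O)C[C@H](O)C[C@H](O)/C=C/n1c(C(C)C)cc(-c2ccncc2)c1-c1ccc(F)cc1`: 5 nM

In an assay for inhibition of 3-hydroxy-3-methylglutaryl-coenzyme A reductase (Rattus norvegicus), using microsomes (on this read-out higher numbers stand for weaker inhibition and lower numbers for stronger inhibition), compound 1 gives 0.3 nM and compound 2 gives 5 nM. Compound 2 therefore stands at the highest of the two numbers, and the gap to compound 1 is beyond the scatter. Among the measured compounds shown here, no pair of these measured compounds differs in only one place, so the two values show only that compound 1 is the stronger inhibitor of the two in this assay.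

Compound 3 `COC(=O)C[C@H](O)C[C@H](O)/C=C/n1c(C(C)C)cc(-c2ccccc2)c1-c1ccc(F)cc1` differs from compound 2 by phenyl in place of pyridin-4-yl on an aromatic carbon. For the measured compounds named here, the data hold no measured step of this kind, so the expectation rests on compound 2 alone. A modest step downward is expected, from compound 2 to compound 3 , of a size close to the edge of the scatter rather than clearly beyond it: a 2.5-fold lower number from compound 2 to compound 3 (0.40 log units; beyond the scatter). For compound 3 the estimated value in this assay is 2 nM, with a range from 0.5 nM to 8 nM.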

Compound 3, half-maximal inhibitory concentration: 2 nM
Estimate against measurement, compound 3: no gap at the digits printed; measured number inside the range.
By their numbers in this assay, from the lowest: compound 1; then compound 3; then compound 2.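

In this assay this aromatic carbon, two ring bonds from the ring nitrogen, takes phenyl in place of pyridin-4-yl with a 2.5-fold lower number from compound 2 to compound 3 (0.40 log units; beyond the scatter), a modest step that is beyond the scatter. Among the compounds shown here, the first measured change in one place thus shows that inhibition here does not rest on the nitrogen of pyridin-4-yl or on the hydrogen-bond acceptor counted for that group, since the all-carbon ring gives the lower number. Nothing measured here accounts for the direction or size of this step.

The compounds shown leave open whether the step depends on where the nitrogen stands in the ring, as pyridin-3-yl would test. They also leave open how this carbon responds to a group of another kind, such as a carboxylic acid or an amine.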